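A few compounds are considered here, and "the series" means these few. Any claim that something is new, unique, unknown or untested is made for them only; others in the source may bear on it.

Measured compounds:
- compound 1, `O=C(O)C[C@H](NC(=O)CN(c1nc(Cl)nc2[nH]cnc12)C1CC1)C(=O)O`, gives 19.9%
- compound 2, `NC(=O)C[C@H](NC(=O)CN(c1ncnc2c1ncn2C1CCCCO1)C1CC1)C(=O)OCc1ccccc1`, gives 34.5%
- compound 3, `O=C(OCc1ccccc1)[C@@H]1CCCN1C(=O)CN(c1ncnc2c1ncn2C1CCCCO1)C1CC1`, gives 32.3%

All three numbers come from a functional assay on the whole organism (Tail, strain ICR) with Mus musculus as the target, in the tail flick test, with a stated time of 30 min, at a dose of 25 umol/kg by the oral route; on this read-out lower numbers stand for a weaker effect and higher numbers for a stronger effect at the one dose given. Compound 1 stands lowest of the three; compound 3 sits higher by a gap beyond the scatter, and compound 2 sits higher still, also beyond the scatter. For the measured compounds named here, compounds 2 and 3 share a core and an ester that compound 1 lacks, so no single-point step links them to compound 1, and their values only set the range seen so far.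

The next compound, compound 4, `NCCCC[C@H](NC(=O)CN(c1nc(Cl)nc2[nH]cnc12)C1CC1)C(=O)O`, keeps the core and the free acid of compound 1 and differs in one place: 3-aminopropyl in place of carboxy on a saturated chain carbon, two bonds along the chain from an amide-type nitrogen and a carbonyl carbon. Going by the values given here, no step of this kind has been measured, so the size of the move in this assay is open. The expectation is a small shift, most likely upward, of a size that may or may not clear the scatter; a large jump in either direction has no support in the three numbers shown.

Compound 4 is estimated at 25%, with a range from 8% to 45%, which means an expected step of a number 5.1 percentage points higher from compound 1 to compound 4 (within the scatter).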

Compound 4, a percentage reported as activity, at one dose (the size of the read-out at that dose, not a potency): 31.2%
Beside the measured number, compound 4's estimate is 6.2 percentage points below it; measured number inside the range.
By their numbers in this assay, from the lowest: compound 1; then compounds 4, 3 and 2 (each within the scatter of the next).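

For the compounds shown here, this is the first single-place step: in this assay, 3-aminopropyl in place of carboxy on a saturated chain carbon, two bonds along the chain from an amide-type nitrogen and a carbonyl carbon, gives a number 11.3 percentage points higher from compound 1 to compound 4 (beyond the scatter). The read-out therefore responds to the group at this position while the core and free acid of compound 1 stay the same, and the two groups carry the same counts of hydrogen-bond donors and acceptors, so those counts do not separate them. No measurement here bears on why the read-out moves with this change.

This single step cannot separate the loss of the carboxy group from the gain of the terminal amine; a plain butyl chain with no amine at this position would help to divide the two contributions. Also open, going by these compounds, are how the response depends on chain length, as with a shorter aminoethyl or a longer aminopentyl chain, and whether the same change holds with a benzyl ester in place of the free acid.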